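Hydrogen in place of benzyl on an amine nitrogen

This account rests on a few compounds, and the source may have more. Where it says the series, first, only, none or still open, it means among the compounds named here.

In a physicochemical assay for lipophilicity, read by HPLC, using the shake flask method (on this read-out lower numbers stand for lower lipophilicity and higher numbers for higher lipophilicity), compound 1 `C/C(=N\C#N)N(Cc1ccccc1)Cc1ccc(Cl)nc1` gives 2.11 and compound 2 `CN(Cc1ccc(Cl)nc1)/C(=N/C#N)c1ccccc1` gives 1.86, so the two stand within the scatter of each other. Compound 3 `C/C(=N\C#N)NCc1ccc(Cl)nc1` differs from compound 1 by hydrogen in place of benzyl on an amine nitrogen. Within the data shown here, no measured pair isolates this change, so the expectation rests on the structural change alone: a step towards lower numbers in this assay, well beyond the scatter. The expected change is a number 1.31 log units lower from compound 1 to compound 3 (beyond the scatter). The estimated value for compound 3 is 0.8, with a range from 0.4 to 1.2.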

Compound 3, partition coefficient: 1.07
The estimate for compound 3 lay 0.27 log units below the measured number, within the range that was stated.
By their numbers in this assay, from the lowest: compound 3; then compounds 2 and 1 (each within the scatter of the next).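

Among these compounds, on the amine nitrogen, hydrogen in place of benzyl is the first single change that can be read: in this assay the step is a number 1.04 log units lower from compound 1 to compound 3 (beyond the scatter). This position therefore responds to the change by more than the scatter. No measurement at hand accounts for the size of this step.

Only the two ends of this change are shown, so it remains open how an ethyl or propyl chain on this nitrogen would read. Equally open, as far as these compounds go, is whether a benzyl carrying a carboxylic acid would stay near compound 1.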